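The source may hold more compounds than are shown below. What is called first, only, known or untested is meant among the compounds shown, and "the series" means these compounds.

Measured compounds: compound 1 `Cc1ccc(NC(=O)c2cnn(-c3ccc(F)cc3)c2C)cc1`, 540 nM; compound 2 `COc1cccc(NC(=O)c2cnn(-c3ccc(F)cc3)c2C)c1`, 3700 nM; compound 3 `Cc1ccccc1NC(=O)c1cnn(-c2ccc(F)cc2)c1C`, 1100 nM; all in a functional assay with Homo sapiens as the target; a lower number here means a stronger inhibitor, a higher number a weaker inhibitor.

Compound 3 stands second highest of the three numbers in this assay: a 2.0-fold higher number from compound 1 to compound 3 (0.31 log units; beyond the scatter) and a 3.4-fold lower number from compound 2 to compound 3 (0.53 log units; beyond the scatter). Compound 4 `CCCCC(CC)NC(=O)c1cnn(-c2ccc(F)cc2)c1C` is not yet measured; it differs from compound 3 by 1-ethylpentyl in place of 2-methylphenyl on an amide-type nitrogen. The measured steps, a 6.9-fold higher number from compound 1 to compound 2 (0.84 log units; beyond the scatter), a 2.0-fold higher number from compound 1 to compound 3 (0.31 log units; beyond the scatter) and a 3.4-fold lower number from compound 2 to compound 3 (0.53 log units; beyond the scatter), each exchange one substituted phenyl for another and keep a ring on the amide-type nitrogen; none removes the ring, so none bears directly on this change. They show only that the series shifts by modest amounts. Without a direct precedent, a modest loss is expected, a 3.2-fold higher number from compound 3 to compound 4 (0.50 log units; beyond the scatter), with a wide range. For compound 4 the estimate is 3500 nM, between 800 nM and 15000 nM.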

Compound 4, half-maximal inhibitory concentration: 580 nM
Compound 4: the middle estimate sits 6.0-fold (0.78 log units) above what was measured; measured number outside the range, below it.
By their numbers in this assay, from the lowest: compounds 1, 4 and 3 (each within the scatter of the next, the first and the last beyond it); then compound 2.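

In this assay a ring on the amide-type nitrogen proves dispensable: 1-ethylpentyl, with no ring, gives a 1.9-fold lower number from compound 3 to compound 4 (0.28 log units; within the scatter) and a 1.1-fold higher number from compound 1 to compound 4 (0.03 log units; within the scatter), so compound 4 stays level with both methylphenyl compounds. The same exchange on the 3-methoxyphenyl compound gives a 6.4-fold lower number from compound 2 to compound 4 (0.80 log units; beyond the scatter) and so matches the pattern of the other two only in the final level reached. No measurement given here explains why the open chain is tolerated.

Open, from the compounds shown here alone, is whether a shorter chain, an unbranched hexyl chain or a cyclohexyl ring holds this level. A chain ending in an amine or a carboxylic acid also remains untested within the compounds shown.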